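Replacing 4-chlorophenyl with 3-fluorophenyl

The compounds below may be only part of what the source reports. "The series", "measured", "known", "first", "only" and "open" are said of these compounds alone.

Compound 1 `CC(=O)N1N=C(c2ccc3ccccc3c2)OC1c1ccccc1Cl`: 4.93 ug/mL
Compound 2 `CC(=O)N1N=C(c2ccc3ccccc3c2)OC1c1ccc(Cl)cc1`: 2.48 ug/mL

In a functional assay on B16-F10 cells (Mus musculus) for antiproliferative activity, read by MTT assay, with a stated time of 48 h (on this read-out lower numbers stand for stronger inhibition and higher numbers for weaker inhibition), compound 2 gives 2.48 ug/mL and compound 1 gives 4.93 ug/mL, so with only these two numbers, compound 2 cannot be told apart from its neighbour. Compound 3 `CC(=O)N1N=C(c2ccc3ccccc3c2)OC1c1cccc(F)c1` has not yet been measured. Its difference from compound 2 is 3-fluorophenyl in place of 4-chlorophenyl on a saturated ring carbon, with the new group on a saturated ring carbon. Among the measured compounds shown here, the only measured step that bears on this change is a 2.0-fold lower number from compound 1 to compound 2 (0.30 log units; within the scatter), where 4-chlorophenyl replaces 2-chlorophenyl. For the measured compounds named here, no measured step involves a fluorine-bearing group, so this is limited guidance, and no step beyond the scatter is expected in this assay. For compound 3 the estimated value is 3.5 ug/mL, with an expected range from 1.4 ug/mL to 9 ug/mL. This expectation amounts to a 1.4-fold higher number from compound 2 to compound 3 (0.15 log units; within the scatter).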

Compound 3, half-maximal inhibitory concentration: 1.61 ug/mL
For compound 3 the middle estimate is 2.2-fold (0.34 log units) above the measured one, and the stated range covers the measured number.
By their numbers in this assay, from the lowest: compounds 3, 2 and 1 (each within the scatter of the next, the first and the last beyond it).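

Replacing 4-chlorophenyl with 3-fluorophenyl on the saturated ring carbon gives a 1.5-fold lower number from compound 2 to compound 3 (0.19 log units; within the scatter), so in this assay these two groups cannot be told apart. Among the compounds shown here, replacing 2-chlorophenyl with 3-fluorophenyl gives a 3.1-fold lower number from compound 1 to compound 3 (0.49 log units; beyond the scatter), the first step to lie beyond the scatter, which shows that a change at this carbon can move the number measurably, though only modestly here. Nothing available gives a reason for this difference.

Because the halogen and its place on the phenyl ring change together in both steps, their separate contributions remain unresolved. Going by these compounds, how an unsubstituted phenyl, or a phenyl carrying a methoxy group or an amine, would read at this carbon also stays open.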